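The source may hold more compounds than are shown below. What is called first, only, known or untested is meant among the compounds shown, and "the series" means these compounds.

Compound 1, `COc1cc(/C(Cl)=C/C=C(\C#N)C(=O)c2c[nH]c3ccccc23)cc(OC)c1OC`, in a functional assay on MCF7 cells (Homo sapiens) for cytotoxicity, read by sulforhodamine B assay, with a stated time of 48 h; on this read-out higher numbers stand for weaker inhibition of growth and lower numbers for stronger inhibition of growth: 4000 nM
Compound 2, `COc1ccc2[nH]cc(C(=O)/C(C#N)=C/C=C(\Cl)c3ccc(OC)c(OC)c3)c2c1`, in this assay: 44900 nM
Compound 3, `COc1ccc(/C(Cl)=C/C=C(\C#N)C(=O)c2c[nH]c3ccc(Br)cc23)cc1`, in this assay: 80300 nM

Among these three numbers compound 2 stands second highest. Its nearest neighbour is compound 3, whose number lies within the usual scatter of it, so the two cannot be told apart. Compound 1 sits far beyond the scatter with a much lower number, meaning clearly stronger inhibition of growth.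

Compound 4, `COc1ccc2[nH]cc(C(=O)/C(C#N)=C/C=C(\Cl)c3ccc(Br)cc3)c2c1`, has not yet been measured. It differs from compound 2 in one place: 4-bromophenyl in place of 3,4-dimethoxyphenyl on a double-bonded chain carbon bound to a chlorine atom and a double-bonded chain carbon. Going by the values given here, no measured pair differs in exactly this way, so no measured step can guide the expectation. The three numbers do show that compound 1, carrying a trimethoxyphenyl, gives the lowest number, while compound 2 and compound 3, carrying fewer methoxy groups, give higher numbers. Compound 4 carries none on that ring, so a step upward in this assay is expected, modest and possibly not beyond the scatter. The step from compound 2 to compound 4 is estimated as a 1.4-fold higher number from compound 2 to compound 4 (0.16 log units; within the scatter). Compound 4 is therefore expected to give about 65000 nM, within a range of 20000 nM to 200000 nM.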

Compound 4, concentration for 50% growth inhibition: 79900 nM
Compound 4: the middle estimate sits 1.2-fold (0.09 log units) below what was measured; measured number inside the range.
By their numbers in this assay, from the lowest: compound 1; then compounds 2, 4 and 3 (each within the scatter of the next).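

In this assay, putting 4-bromophenyl in place of 3,4-dimethoxyphenyl on a double-bonded chain carbon bound to a chlorine atom and a double-bonded chain carbon gives a 1.8-fold higher number from compound 2 to compound 4 (0.25 log units; within the scatter). Going by these compounds alone, this is the first direct comparison at this position, and it shows that this exchange, which removes both methoxy groups and brings in a bromine, leaves the two compounds indistinguishable on this read-out. No other measurement is available to help interpret this result.

Compound 1, at 4000 nM, differs from compound 2 and compound 4 in more than one place, so the part played by its aryl ring in its much lower number remains unresolved. On these data alone, it also remains open whether a group of another kind at this position, such as an amine or a carboxylic acid, would move the number beyond the scatter.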